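The source may report more compounds than this note shows. Statements on the series, on what has been measured and on what is new or still open speak of the compounds shown alone.

Compound 3 `Cc1ccc(S(=O)(=O)/C(=C/c2ccc(N(C)C)cc2)C(=O)c2ccc(Cl)cc2)cc1` is the starting point. In a functional assay on DU-145 cells (Homo sapiens) for inhibition, read by trypan blue exclusion, with a stated time of 96 h (a higher number here means a weaker inhibitor of growth, a lower number a stronger inhibitor of growth), compound 3 gives > 100000 nM, which is a limit of the assay and not a number. Compound 4 `CN(C)c1ccc(/C=C(/SCc2ccc(Cl)c(Cl)c2)C(=O)c2ccc(Cl)cc2)cc1` keeps the rest of compound 3 and alters one group: (3,4-dichlorobenzyl)sulfanyl in place of (4-methylphenyl)sulfonyl on a double-bonded chain carbon bound to a carbonyl carbon and a double-bonded chain carbon.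

Among the compounds with values here, no measured step covers this swap directly. The nearest evidence comes from two compounds that already carry the (3,4-dichlorobenzyl)sulfanyl group. In this assay compound 1 `COc1ccccc1/C=C(/SCc1ccc(Cl)c(Cl)c1)C(=O)c1ccc(Cl)cc1` gives 10000 nM, and compound 2 `Cc1ccsc1/C=C(/SCc1ccc(Cl)c(Cl)c1)C(=O)c1ccc(Cl)cc1` gives 50000 nM. Within the data shown here, the one measured step is a 5.0-fold higher number from compound 1 to compound 2 (0.70 log units; beyond the scatter), with 3-methylthiophen-2-yl in place of 2-methoxyphenyl. It concerns a different group, so it only shows how far values can move among compounds that hold the incoming group.

Both of these compounds gave real numbers, so a move towards a lower number, meaning a stronger inhibitor, seems likely. The expected step is an at least 5.0-fold lower number from compound 3 to compound 4 (0.69 log units; beyond the scatter). From the compounds shown here alone, its true size stays open, since the starting value is only a limit. For compound 4 the estimated value is 20000 nM, with an expected range from 5000 nM to 80000 nM.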

Compound 4, concentration for 50% growth inhibition: 50000 nM
The estimate for compound 4 lay 2.5-fold (0.40 log units) below the measured number; the range from low to high includes it.
By their numbers in this assay, from the lowest: compound 1; then compounds 2 and 4 (each within the scatter of the next). At a limit, above all of these: compound 3.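

Replacing (4-methylphenyl)sulfonyl with (3,4-dichlorobenzyl)sulfanyl on a double-bonded chain carbon bound to a carbonyl carbon and a double-bonded chain carbon gives an at least 2.0-fold lower number from compound 3 to compound 4 (0.30 log units; that floor lies within the scatter), so this pair alone does not establish a real improvement at this position. Among the compounds carrying the (3,4-dichlorobenzyl)sulfanyl group, changing the other group gives no change at the digits printed from compound 2 to compound 4 (within the scatter) for 4-(dimethylamino)phenyl in place of 3-methylthiophen-2-yl, and a 5.0-fold higher number from compound 1 to compound 4 (0.70 log units; beyond the scatter) for 4-(dimethylamino)phenyl in place of 2-methoxyphenyl, so the 2-methoxyphenyl compound stands apart from the other two. Compound 3 is held at a limit and not a number, so the true size of the swap cannot be read: the limit of > 100000 nM in this assay, at which 1 of the 4 values shown sits.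

The two exchanged groups differ in the sulfur's oxidation state, in the chlorines and in the benzyl link all at once, so the compounds shown leave open which of these features matters. A (3,4-dichlorobenzyl)sulfonyl group or a (4-methylphenyl)sulfanyl group at the same carbon would begin to separate them, and an unsubstituted benzylsulfanyl group would address the two chlorines.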